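A few compounds are considered here, and "the series" means these few. Any claim that something is new, unique, unknown or untested is made for them only; others in the source may bear on it.

In a functional assay on L1210 cells (Mus musculus) for antiproliferative activity, with a stated time of 48 h (a lower number here means a stronger inhibitor, a higher number a weaker inhibitor), compound 1 `C=C(Br)C(=O)Nc1ccc(C(=O)/C=C/c2cccc(OC)c2)cc1` gives 1100 nM, compound 2 `C=C(Br)C(=O)Nc1ccc(C(=O)/C=C/c2ccc(OC)c(OC)c2)cc1` gives 1300 nM and compound 3 `C=C(Br)C(=O)Nc1ccc(C(=O)/C=C/c2cc(OC)c(OC)c(OC)c2)cc1` gives 1500 nM. Compound 2 thus sits in a close group and cannot be separated from compound 1 or compound 3, since its steps to both lie within the scatter.

Compound 4 `C=C(Br)C(=O)Nc1ccc(C(=O)/C=C/c2ccc(OC)c(OC)c2OC)cc1` has not yet been measured. It departs from compound 2 by methoxy in place of hydrogen on an aromatic carbon, which is methoxy in place of hydrogen on an aromatic carbon, here ortho to a large group, ortho to a methoxy group and meta to a methoxy group.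

Within the data shown here, two measured steps bear on this change, as both are the same replacement: a 1.2-fold higher number from compound 1 to compound 2 (0.07 log units; within the scatter) and a 1.2-fold higher number from compound 2 to compound 3 (0.06 log units; within the scatter). Each is small and within the scatter. Neither, however, places the methoxy ortho to a large group, so they cover the new compound only in part. No shift beyond the scatter is therefore expected in this assay, and no firm direction either. The expected move is a 1.2-fold higher number from compound 2 to compound 4 (0.06 log units; within the scatter). For compound 4 the estimated value is 1500 nM, with an expected range from 750 nM to 3000 nM, kept wide for the untested placement.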

Compound 4, half-maximal inhibitory concentration: 630 nM
Beside the measured number, compound 4's estimate is 2.4-fold (0.38 log units) above it; the measured number lies below the stated range.
By their numbers in this assay, from the lowest: compounds 4, 1, 2 and 3 (each within the scatter of the next, the first and the last beyond it).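

In this assay, methoxy in place of hydrogen, ortho to a large group, ortho to a methoxy group and meta to a methoxy group, gives a 2.1-fold lower number from compound 2 to compound 4 (0.31 log units; beyond the scatter), a modest step but the only one of this replacement shown here that lies beyond the scatter. The same replacement on compound 2 in another placement gives a 1.2-fold higher number from compound 2 to compound 3 (0.06 log units; within the scatter), which stays within the scatter, as does a 1.2-fold higher number from compound 1 to compound 2 (0.07 log units; within the scatter), so the outcome of adding a methoxy group to this ring depends on where it goes, at least in these compounds. The data offered here give no explanation for this difference.

On these data alone, it remains open whether the lower number belongs to methoxy itself or would also follow from another group in the same place, such as a hydroxyl group, a chlorine atom or an ethoxy group. As far as these compounds go, it is also open whether the step would persist on a ring lacking the two methoxy groups already carried by compound 2, as this placement appears here only alongside them.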